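Swapping the Amide Substituent of Compound 2

The source may report more compounds than this note shows. Statements on the series, on what has been measured and on what is new or still open speak of the compounds shown alone.

Going by the values given here, in a functional assay on FaDu cells (Homo sapiens) for cytotoxicity, read by MTT assay, with a stated time of 72 h (on this read-out higher numbers stand for lower toxicity in this test and lower numbers for higher toxicity in this test), only two compounds have numbers so far. Compound 1 (`COc1ccc(NC(=O)C(=O)c2cn(C(C)C)c3cccc(OC)c23)cn1`) gives 7780 nM in this test, and compound 2 (`COc1ccc(NC(=O)C(=O)c2cn(C(C)C)c3ccccc23)nn1`) gives 2270 nM in the same test. Compound 2 therefore holds the lower of the two numbers, and its gap to compound 1 lies beyond the scatter. The two compounds differ in more than one place, so that gap cannot be tied to any single change.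

Compound 3 (`COc1ccc(NC(=O)C(=O)c2cn(C(C)C)c3ccccc23)cn1`) has 6-methoxypyridin-3-yl in place of 6-methoxypyridazin-3-yl on an amide-type nitrogen. It keeps the core of compound 2 and shares its 6-methoxypyridin-3-yl with compound 1. Among the compounds with values here, no measured pair isolates this exchange, so the data offer no direct guide to its size. With compound 2 at 2270 nM as the closest anchor, no step beyond the scatter is expected in this assay for this exchange, though with wide uncertainty. The expected step is a 1.7-fold lower number from compound 2 to compound 3 (0.24 log units; within the scatter) and remains only an estimate. For compound 3 the estimated value is 1300 nM with an expected range from 200 nM to 6000 nM in this test.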

Compound 3, concentration lethal to 50% of the cells: 85 nM
Compound 3: middle estimate off by 15-fold (1.18 log units), on the high side; measured number below the stated range.
By their numbers in this assay, from the lowest: compound 3; then compound 2; then compound 1.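

In this assay, the exchange of 6-methoxypyridazin-3-yl for 6-methoxypyridin-3-yl on the amide-type nitrogen now stands alone and brings a 27-fold lower number from compound 2 to compound 3 (1.43 log units; beyond the scatter), so this place responds strongly to a change of a single ring hetero atom, with the heavy-atom count of the group unchanged. Compound 3 also isolates a second place in the shared core: hydrogen in place of methoxy on an aromatic carbon brings a 92-fold lower number from compound 1 to compound 3 (1.96 log units; beyond the scatter), so the methoxy-bearing compound 1 is far less toxic in this test than its hydrogen counterpart, a difference the earlier pair could not assign to either place. Nothing available explains why either exchange has so large an effect.

The compounds shown leave open how other groups on the amide-type nitrogen would behave, such as an unsubstituted pyridin-3-yl or a 6-aminopyridin-3-yl, and whether the methoxy group matters because of its oxygen or its size, which a fluorine, a hydroxyl or an ethoxy group on that aromatic carbon could begin to separate. They also leave open whether the two steps would hold if both places were changed together, as in compound 2 carrying the methoxy group on the core.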